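This account rests on a few compounds, and the source may have more. Where it says the series, first, only, none or still open, it means among the compounds named here.

Of the compounds shown here, three on a shared core have been measured, and a fourth awaits its number. In an ADME assay on RAW264.7 cells (Mus musculus) for cytotoxicity, read by MTT assay, with a stated time of 72 h, tested at 100 uM (on this read-out higher numbers stand for a stronger effect at the one concentration tested and lower numbers for a weaker effect), compound 1 `O=C(Cn1c(=O)oc2cc(Cl)ccc21)Nc1ccccc1` gives 20.2%. In this assay compound 2 `O=C(Cn1c(=O)oc2cc([N+](=O)[O-])ccc21)Nc1ccccc1` gives 26.4%. In this assay compound 3 `O=C(Cn1c(=O)oc2cc([N+](=O)[O-])ccc21)NCc1ccccn1` gives 33.4%; its distance to compound 1 lies beyond the scatter, while its distance to compound 2 lies within it. Compound 4 `O=C(Cn1c(=O)oc2cc(Cl)ccc21)NCc1ccccn1` is not yet measured. It differs from compound 3 by chloro in place of nitro on an aromatic carbon. The same change occurs once among the measured compounds, from compound 2 to compound 1, as chloro in place of nitro on an aromatic carbon, and there it made a number 6.2 percentage points lower from compound 2 to compound 1 (within the scatter). The cores of compound 2 and compound 3 differ by (pyridin-2-yl)methyl in place of phenyl on an amide-type nitrogen, and that step made a number 7 percentage points higher from compound 2 to compound 3 (within the scatter). Because the same change made a number 6.2 percentage points lower from compound 2 to compound 1 (within the scatter) when it was applied before, the step now expected is a number 6.4 percentage points lower from compound 3 to compound 4 (within the scatter), again a small one. On that basis compound 4 is estimated at 27%, with a likely range from 17% to 37%.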

Compound 4, a percentage reported as inhibition, at one concentration (the size of the read-out at that concentration, not a potency): 40%
Beside the measured number, compound 4's estimate is 13 percentage points below it; measured number outside the range, above it.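

In this assay, chloro in place of nitro on an aromatic carbon gave a number 6.6 percentage points higher from compound 3 to compound 4 (within the scatter), and the two instances of this change cannot be told apart: the same change on two cores in this assay, a number 6.2 percentage points lower (within the scatter) from compound 2 to compound 1 and a number 6.6 percentage points higher (within the scatter) from compound 3 to compound 4, 12.8 percentage points apart, within the scatter of two such steps. Exchanging phenyl for (pyridin-2-yl)methyl on the amide-type nitrogen gave a number 19.8 percentage points higher from compound 1 to compound 4 (beyond the scatter), and this change also carries across the two cores within the expected scatter: the same change on two cores in this assay, a number 7 percentage points higher (within the scatter) from compound 2 to compound 3 and a number 19.8 percentage points higher (beyond the scatter) from compound 1 to compound 4, 12.8 percentage points apart, within the scatter of two such steps. This shows that neither change differed measurably between the two cores, but it does not establish a direction for the chloro step, and two instances of each change cannot show that either would carry to other cores in the series.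

The compounds shown leave open whether a methoxy group or an amine on that aromatic carbon, or a longer chain on the amide-type nitrogen, would give a different read-out. With one concentration per compound, they also tell only of a stronger or weaker effect at that concentration and leave open how the effect would stand at other concentrations.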